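Swapping the Carbonyl Substituent in Two Limit-Bound Compounds

A few compounds are considered here, and "the series" means these few. Any claim that something is new, unique, unknown or untested is made for them only; others in the source may bear on it.

Compound 1: `COc1cc(-c2nn(-c3cccc(NC(=O)Nc4ccc(Cl)c(Cl)c4)c3)cc2-c2ccncc2)ccc1Cl` — > 50000 nM
Compound 2: `COc1cc(-c2nn(-c3cccc(NC(=O)Nc4cccc(C(F)(F)F)c4)c3)cc2-c2ccncc2)ccc1Cl` — > 50000 nM

Both measured compounds were tested in a functional assay on SR cells (Homo sapiens) for inhibition, read by sulforhodamine B assay, with a stated time of 48 h; on this read-out lower numbers stand for higher toxicity in this test and higher numbers for lower toxicity in this test. Compound 1 gives no number there, only the limit > 50000 nM. Compound 2 likewise returns only the limit, > 50000 nM. For the measured compounds named here, the single step between them, 3-(trifluoromethyl)phenyl in place of 3,4-dichlorophenyl on an amide-type nitrogen, is therefore a step that the two limits leave unreadable from compound 1 to compound 2; the only evidence available is the limit of > 50000 nM in this assay, at which 2 of the 2 values shown sit, which says where both values sit but not how far apart they are.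

Compound 3, `COc1cc(-c2nn(-c3cccc(NC(=O)c4ccc(Cl)c(C(F)(F)F)c4)c3)cc2-c2ccncc2)ccc1Cl`, changes the carbonyl side of compound 2: 4-chloro-3-(trifluoromethyl)phenyl in place of (3-(trifluoromethyl)phenyl)amino on a carbonyl carbon. Going by the values given here, no measured step touches this part of the molecule, and the one step that exists is unreadable, so nothing in the data points to a move of either sign. The step from compound 2 to compound 3 is expected to be a step that the limit leaves unreadable from compound 2 to compound 3, that is, none beyond the scatter. Compound 3 is accordingly estimated at 60000 nM, within 20000 nM to 150000 nM, with a real chance that this assay again reports only a limit for compound 3.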

Compound 3, concentration lethal to 50% of the cells: > 32500 nM
Compound 3 was reported as a limit (the forecaster's own chance of this, stated with the estimate: 65%); the middle value is on the limit's open side.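

Compound 3 also gives only a limit in this assay, > 32500 nM. For the compounds shown here, compound 1 and compound 2 are limits too, so no step among the three compounds can be read. The compounds shown leave open where the true values of all three lie and how far apart they are.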